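Swapping the Terminal Ring: Pyrrolidine to Piperidine

The compounds below may be only part of what the source reports. "The series", "measured", "known", "first", "only" and "open" are said of these compounds alone.

Of the compounds shown here, two have been tested so far in a functional assay on NCI-H460 cells (Homo sapiens) for inhibition, read by MTT assay, with a stated time of 72 h; on this read-out higher numbers stand for weaker inhibition and lower numbers for stronger inhibition. Compound 2 `COc1cc2c(Oc3ccc(NC(=O)c4nn(-c5ccc(Cl)cc5)c(=O)cc4C)cc3F)ccnc2cc1OCCCN1CCCC1` gives 360 nM in this assay, the higher of the two numbers; compound 1 `COc1cc2c(Oc3ccc(NC(=O)c4nn(-c5ccccc5C(F)(F)F)c(=O)cc4C)cc3F)ccnc2cc1OCCCN1CCCCC1` gives 210 nM, and the gap between them lies within the scatter, so the two are not distinguished.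

Compound 3 `COc1cc2c(Oc3ccc(NC(=O)c4nn(-c5ccc(Cl)cc5)c(=O)cc4C)cc3F)ccnc2cc1OCCCN1CCCCC1` differs from compound 2 in one place: piperidin-1-yl in place of pyrrolidin-1-yl on a saturated chain carbon, three bonds along the chain from an oxygen on an aromatic ring. Going by the values given here, no step between measured compounds with this single change is known, so the expected effect rests on the change alone, and it is a modest one at the far end of a flexible chain. The step from compound 2 to compound 3 is therefore expected to be small, a 1.2-fold lower number from compound 2 to compound 3 (0.08 log units; within the scatter), and not beyond the scatter in either direction. On that basis compound 3 is estimated to give 300 nM in this assay, within a range from 120 nM to 750 nM.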

Compound 3, half-maximal inhibitory concentration: 460 nM
Beside the measured number, compound 3's estimate is 1.5-fold (0.19 log units) below it, within the range that was stated.
By their numbers in this assay, from the lowest: compounds 1, 2 and 3 (each within the scatter of the next, the first and the last beyond it).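

In this assay, replacing the 3-(pyrrolidin-1-yl)propyl chain with 3-(piperidin-1-yl)propyl gives a 1.3-fold higher number from compound 2 to compound 3 (0.11 log units; within the scatter), so these two terminal rings cannot be told apart at this position. Compound 3 also makes it possible to read the group on the aromatic nitrogen on its own: 4-chlorophenyl in place of 2-(trifluoromethyl)phenyl gives a 2.2-fold higher number from compound 1 to compound 3 (0.34 log units; beyond the scatter), a modest step but one beyond the scatter, whereas the two earlier compounds differed in two places at once. Nothing available explains either step.

The compounds shown leave open whether a morpholine ring or an open dimethylamino group at the end of the chain would also fit this flat picture. They also leave open how a shorter 2-(piperidin-1-yl)ethyl chain would behave.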